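The source may hold more compounds than are shown below. What is called first, only, known or untested is meant among the compounds shown, and "the series" means these compounds.

- Compound 1 `Cc1ccc(S(=O)(=O)N[C@@H](CC(=O)NC(C)(C)C)C(=O)NCCNC(=O)c2cc(C)ccn2)cc1`: > 11100 nM (a limit)
- Compound 2 `Cc1ccc(S(=O)(=O)N[C@@H](CC(=O)NC(C)(C)C)C(=O)NCCNC(=O)c2ccccc2O)cc1`: > 11100 nM (a limit)

In an ADME assay on Karpas-1106P cells (Homo sapiens) for cytotoxicity (on this read-out lower numbers stand for an effect already at smaller amounts and higher numbers for an effect only at larger amounts of compound), compound 2 stands at a limit, > 11100 nM, and not at a number. The evidence so far is the limit of > 11100 nM in this assay, at which 2 of the 2 values shown sit.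

Compound 3 `Cc1ccc(S(=O)(=O)N[C@@H](CC(=O)NC(C)(C)C)C(=O)NCCNC(=O)c2cccc(C(F)(F)F)c2)cc1` has not yet been measured. It carries 3-(trifluoromethyl)phenyl in place of 2-hydroxyphenyl on a carbonyl carbon. The change counts as follows: 3-(trifluoromethyl)phenyl in place of 2-hydroxyphenyl on a carbonyl carbon.

For the measured compounds named here, only one measured step bears on this change, as it also swaps the group on that carbonyl carbon: a step that the two limits leave unreadable from compound 1 to compound 2. It offers no size to carry over, so no shift beyond the usual scatter can be predicted in either direction. The expected change is a number no higher from compound 2 to compound 3 (the limit leaves the size open). Compound 3 is estimated at 11100 nM, with an expected range from 4000 nM to 30000 nM.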

Compound 3, half-maximal effective concentration: > 11100 nM
Compound 3 ended at the assay's limit; the forecaster's own chance of this, stated with the estimate: 75%; the middle value sits exactly at the limit.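

In this assay the steps to compound 3 from compound 1 and compound 2 cannot be read, because all three values are limits and not numbers: the limit of > 11100 nM in this assay, at which 3 of the 3 values shown sit. The compounds shown leave open at what concentration any of them would show an effect, and whether swapping the group on the carbonyl carbon changes that concentration.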